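The source may report more compounds than this note shows. Statements on the series, on what has been measured and on what is new or still open speak of the compounds shown alone.

Three compounds built on one shared core enter this account: compound 1 `O=C(NCc1ccccc1)c1cn(-c2ccccc2)nc1-c1cccnc1`, compound 2 `COc1ccc(OC(=O)c2cn(-c3ccccc3)nc2-c2cccnc2)cc1` and compound 3 `CC(C)(C)c1ccc(OC(=O)c2cn(-c3ccccc3)nc2-c2cccnc2)cc1`. In a functional assay on MCF7 cells (Homo sapiens) for cytotoxicity, read by MTT assay, with a stated time of 48 h (on this read-out lower numbers stand for stronger inhibition and higher numbers for weaker inhibition), compound 1 gave "nd(insoluble)" (no result reported), so no number stands for it. Compound 2 reached only a limit of the assay in this assay, > 100000 nM. Compound 3 also gave only a limit, > 100000 nM. The step that the two limits leave unreadable from compound 2 to compound 3, tert-butyl in place of methoxy on an aromatic carbon, is therefore of unreadable size. Compound 2 thus stands at the limit, as does (the limit of > 100000 nM in this assay, at which 2 of the 3 values shown sit), with one further compound undetermined.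

The compound to be measured is compound 4 `Cc1ccc(C(C)C)c(OC(=O)c2cn(-c3ccccc3)nc2-c2cccnc2)c1`. It differs from compound 2 by 2-isopropyl-5-methylphenyl in place of 4-methoxyphenyl on an oxygen next to a carbonyl group. For the measured compounds named here, the only measured step that bears on this change, from compound 2 to compound 3, is itself hidden by the two limits, so it gives no direction and no size. The account therefore expects no step beyond the scatter for compound 4 in this assay and foresees that it, too, will most likely sit at the limit. The estimate for compound 4 is 150000 nM, with a range from 40000 nM to 500000 nM, which amounts to an expected step that the limit leaves unreadable from compound 2 to compound 4.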

Compound 4, half-maximal inhibitory concentration: 84200 nM
For compound 4 the middle estimate is 1.8-fold (0.25 log units) above the measured one, and the stated range covers the measured number.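

In this assay compound 4 is the only compound shown that gives a number rather than a limit, so 2-isopropyl-5-methylphenyl on an oxygen next to a carbonyl group is the first change here that brings a value into the readable range. Set against 4-methoxyphenyl, the change reads as an at least 1.1-fold lower number from compound 2 to compound 4 (0.07 log units; that floor lies within the scatter), and set against 4-(tert-butyl)phenyl it reads as an at least 1.1-fold lower number from compound 3 to compound 4 (0.07 log units; that floor lies within the scatter); each is only a floor, so the result shows that a number can be obtained at this position but does not establish a real difference in size. The other two measured compounds remain where they were, and the position as a whole still stays close to that edge: the limit of > 100000 nM in this assay, at which 2 of the 4 values shown sit.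

On these data alone, how large the two steps really are stays open, as does the unreadable step between the two compounds at the limit, and so does whether the value of compound 4 depends on the isopropyl group, the methyl group or both. Also open, as far as these compounds go, is how this position would respond to an aromatic ring carrying an amine or a carboxylic acid.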